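The source may hold more compounds than are shown below. What is called first, only, known or untested is meant among the compounds shown, and "the series" means these compounds.

Working notes on a series built on one shared core, which carries a trifluoromethyl group and differs in the ester or acid and in the aryl group on the five-membered ring.

Compound 1 `CCOC(=O)C1=Cc2ccccc2OC1(OCc1cn(-c2cccc(OC)c2)nn1)C(F)(F)F` is the reference for the assay floor. In a functional assay on DU-145 cells (Homo sapiens) for inhibition, read by MTT assay, with a stated time of 24 h (a lower number here means a stronger inhibitor, a higher number a weaker inhibitor), compound 1 returns only a limit, > 150000 nM. That limit is a boundary of the assay, not a number, and it is noted separately: the limit of > 150000 nM in this assay, at which 1 of the 3 values shown sits.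

Compound 2 `CCOC(=O)C1=Cc2ccccc2OC1(OCc1cc(-c2ccc3ccccc3c2)no1)C(F)(F)F` gives 71800 nM in this assay. Compound 3 `O=C(O)C1=Cc2ccccc2OC1(OCc1cc(-c2ccc([N+](=O)[O-])cc2)no1)C(F)(F)F` gives 100000 nM in this assay. Among the two numbers shown, compound 2 holds the lower one, but the gap to compound 3 lies within the scatter, so no order between them is claimed.

Compound 4 `CCOC(=O)C1=Cc2ccccc2OC1(OCc1cc(-c2ccc(Cl)cc2)no1)C(F)(F)F` has not yet been measured. Relative to compound 2 the change is 4-chlorophenyl in place of naphthalen-2-yl on an aromatic carbon. Among the measured compounds shown here, no measured pair in the set carries this exchange, so its size is open. The expectation is a step of a 1.4-fold higher number from compound 2 to compound 4 (0.14 log units; within the scatter), a modest move toward a higher number and close to the scatter. Compound 4 is therefore estimated at 100000 nM, with a range from 40000 nM to 200000 nM.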

Compound 4, half-maximal inhibitory concentration: 18200 nM
Compound 4: middle estimate off by 5.5-fold (0.74 log units), on the high side; the whole stated range lies above it.
By their numbers in this assay, from the lowest: compound 4; then compounds 2 and 3 (each within the scatter of the next). At a limit, above all of these: compound 1.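

The step at this position, on an aromatic carbon of the five-membered aromatic ring with 1 nitrogen and 1 oxygen, next to the ring nitrogen, shows that the aryl group there can change the read-out in this assay: 4-chlorophenyl in place of naphthalen-2-yl gives a 3.9-fold lower number from compound 2 to compound 4 (0.60 log units; beyond the scatter) and lies beyond the scatter. Among the compounds shown here, the earlier compounds offered no pair differing in one place, so this is the first evidence that the series responds to a single exchange, and here the answer favours one six-membered aromatic ring of carbon only, bearing chlorine, over the two-ring group. The exchange leaves the hydrogen-bond donor and acceptor counts of the group unchanged, with 0 of each on both sides, so the step arises without any change in those counts.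

What sets the size of this step is left open, and no measured property among the compounds shown bears on it. A plain phenyl or a 4-aminophenyl group on this carbon would separate the effect of the chlorine from that of the second ring, while the ethyl ester and the carboxylic acid remain unseparated, as compound 3 also differs in its aryl group.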